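Aryl change on the triazole nitrogen: compound 4 expected

This account rests on a few compounds, and the source may have more. Where it says the series, first, only, none or still open, it means among the compounds named here.

Compound 2 `COc1ccccc1-n1nncc1CN1C(=O)C2(C(C#N)=C(N)Oc3c2c2nc4ccccc4nc2c2ccccc32)c2ccccc21` and its neighbours compound 1 `Cc1ccccc1-n1nncc1CN1C(=O)C2(C(C#N)=C(N)Oc3c2c2nc4ccccc4nc2c2ccccc32)c2ccccc21` and compound 3 `CCOc1ccccc1-n1nncc1CN1C(=O)C2(C(C#N)=C(N)Oc3c2c2nc4ccccc4nc2c2ccccc32)c2ccccc21` share one core and differ only in the group on the aromatic nitrogen of the five-membered ring with three nitrogens. In an ADME assay on HUVEC cells (Homo sapiens) for antiproliferative activity, read by MTT assay, with a stated time of 48 h (a lower number here means a stronger inhibitor, a higher number a weaker inhibitor), compound 1 gives > 50000 nM, a limit of the assay and not a number. Compound 2 gives > 50000 nM in this assay, again a limit. Compound 3 likewise gives > 50000 nM in this assay, also a limit. The steps a step that the two limits leave unreadable from compound 1 to compound 2, a step that the two limits leave unreadable from compound 1 to compound 3 and a step that the two limits leave unreadable from compound 2 to compound 3 cannot be read because of the limit of > 50000 nM in this assay, at which 3 of the 3 values shown sit. Compound 2 thus stands where every measured compound stands, at the limit, with nothing to set it apart.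

Compound 4 `Cc1ccc(-n2nncc2CN2C(=O)C3(C(C#N)=C(N)Oc4c3c3nc5ccccc5nc3c3ccccc43)c3ccccc32)cc1Cl` is built from compound 2 by 3-chloro-4-methylphenyl in place of 2-methoxyphenyl on an aromatic nitrogen. Among the measured compounds shown here, the only measured steps that bear on this change are the three above, all between limits, and none of them yields a size. Since nothing measured shows a group on that aromatic nitrogen moving the read-out off the limit, no direction beyond the scatter is expected for a step that the limit leaves unreadable from compound 2 to compound 4. The expectation is that compound 4 also returns a limit in this assay. For compound 4 the estimate in this assay is 60000 nM, with a range from 20000 nM to 200000 nM.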

Compound 4, half-maximal inhibitory concentration: > 50000 nM
Compound 4 gave a limit, no number; the forecaster's own chance of this, stated with the estimate: 85%; the middle value is on the limit's open side.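

No new step can be read from compound 4 to compound 1, compound 2 or compound 3, because each result is a limit and not a number: the limit of > 50000 nM in this assay, at which 4 of the 4 values shown sit.

The compounds shown leave open whether any group on the triazole's aromatic nitrogen moves the read-out off the limit in this assay, and how far these four compounds differ.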